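Replacing the Aryl Group on the Enone Chain

A few compounds are considered here, and "the series" means these few. Any claim that something is new, unique, unknown or untested is made for them only; others in the source may bear on it.

Compound 1 `COc1ccc(/C=C/C(=O)c2cc(-c3cc(OC)c(OC)c(OC)c3)n3nc(-c4ccccc4)cc3n2)cc1OC` gives 14200 nM in a functional assay on MDA-MB-231 cells (Homo sapiens) for antiproliferative activity, read by MTT assay, with a stated time of 24 h; a higher number here means a weaker inhibitor, a lower number a stronger inhibitor.
Compound 2 `COc1ccc(/C=C/C(=O)c2cc(-c3cc(OC)c(OC)c(OC)c3)n3nc(-c4ccccc4)cc3n2)cc1` gives 16500 nM in this assay.
Compound 3 `COc1cc(-c2cc(C(=O)/C=C/c3ccc(C)cc3)nc3cc(-c4ccccc4)nn23)cc(OC)c1OC` gives 18600 nM in this assay.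

Compound 3 has the highest number of the three, but neither neighbour is separated from it beyond the scatter: a 1.3-fold higher number from compound 1 to compound 3 (0.12 log units; within the scatter) and a 1.1-fold higher number from compound 2 to compound 3 (0.05 log units; within the scatter). All three compounds are, in effect, indistinguishable in this assay.

Compound 4 `COc1cc(/C=C/C(=O)c2cc(-c3cc(OC)c(OC)c(OC)c3)n3nc(-c4ccccc4)cc3n2)cc(OC)c1OC` differs from compound 3 in one place: 3,4,5-trimethoxyphenyl in place of 4-methylphenyl on a double-bonded chain carbon bound to a double-bonded chain carbon. Among the compounds with values here, the steps that bear on this change all sit at the same place or on the same ring. Swapping the 3,4-dimethoxyphenyl for the 4-methylphenyl gave a 1.3-fold higher number from compound 1 to compound 3 (0.12 log units; within the scatter); removing a methoxy from an aromatic carbon gave a 1.2-fold higher number from compound 1 to compound 2 (0.07 log units; within the scatter); exchanging methoxy for methyl on an aromatic carbon gave a 1.1-fold higher number from compound 2 to compound 3 (0.05 log units; within the scatter). None of these moved the number beyond the scatter, so returning to a methoxy-bearing ring, now with a third methoxy, is expected to give no step beyond the scatter either: a 1.2-fold lower number from compound 3 to compound 4 (0.09 log units; within the scatter). Compound 4 is therefore estimated at 15000 nM, with a range of 7000 nM to 35000 nM.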

Compound 4, half-maximal inhibitory concentration: 18400 nM
Beside the measured number, compound 4's estimate is 1.2-fold (0.09 log units) below it; the range from low to high includes it.
By their numbers in this assay, from the lowest: compounds 1, 2, 4 and 3 (each within the scatter of the next).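

The 3,4,5-trimethoxyphenyl group has 12 heavy atoms and 3 hydrogen-bond acceptors, against 7 heavy atoms and 0 acceptors for 4-methylphenyl, yet in this assay this swap gives a 1.0-fold lower number from compound 3 to compound 4 (0.00 log units; within the scatter) on the chain. The comparisons with the methoxy-bearing rings agree: 3,4,5-trimethoxyphenyl in place of 4-methoxyphenyl gives a 1.1-fold higher number from compound 2 to compound 4 (0.05 log units; within the scatter), and methoxy in place of hydrogen on an aromatic carbon gives a 1.3-fold higher number from compound 1 to compound 4 (0.11 log units; within the scatter). So even this larger change to the aryl group on the enone chain produces no step beyond the scatter.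

Nothing available explains why the number responds so little to these changes. From the compounds shown here alone, all four rings at this position carry only methoxy or methyl groups, so it remains open whether an amine or a carboxylic acid on this ring would move the number beyond the scatter.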